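A few compounds are considered here, and "the series" means these few. Any claim that something is new, unique, unknown or untested is made for them only; others in the source may bear on it.

Measured so far:
compound 1, `CC(C)Oc1cc(C(C)(C)C)ccc1C/N=C(\S)NCc1ccc(NS(C)(=O)=O)cc1` — in a functional assay for inhibition of Vanilloid receptor (Rattus norvegicus) (a lower number here means a stronger inhibitor, a higher number a weaker inhibitor), compound 1 gives 350 nM
compound 2, `CC(C)(C)COc1cc(C(C)(C)C)ccc1C/N=C(\S)NCc1ccc(NS(C)(=O)=O)cc1` — in this assay compound 2 gives 60 nM

Compound 2 holds the lowest number of the two; the nearest, compound 1, sits higher by a 5.8-fold lower number from compound 1 to compound 2 (0.77 log units; beyond the scatter), a step beyond the scatter.

The next step goes from compound 2 to compound 3, `CC(=O)OCc1cc(C(C)(C)C)ccc1C/N=C(\S)NCc1ccc(NS(C)(=O)=O)cc1`. The change is acetoxymethyl in place of neopentyloxy on an aromatic carbon. Among the measured compounds shown here, the group that leaves is the one whose entry produced the only measured step, a 5.8-fold lower number from compound 1 to compound 2 (0.77 log units; beyond the scatter), where neopentyl replaced isopropyl on the oxygen. That step bears on the present change only loosely: it shows that, on this aromatic carbon, the choice of group moved the number by a modest amount, and that the neopentyloxy of compound 2 was the better of the two groups tried. For the measured compounds named here, no measured pair shows an acetoxymethyl or any group of the kind entering here, so the direction of this assay for compound 3 rests on one comparison.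

Given that removing the neopentyloxy undoes the gain seen in a 5.8-fold lower number from compound 1 to compound 2 (0.77 log units; beyond the scatter), compound 3 is expected to return toward the number of compound 1, a step of roughly a 5.0-fold higher number from compound 2 to compound 3 (0.70 log units; beyond the scatter). The estimate for compound 3 is 300 nM, with a range from 80 nM to 1200 nM.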

Compound 3, half-maximal inhibitory concentration: 580 nM
Compound 3: middle estimate off by 1.9-fold (0.29 log units), on the low side, within the range that was stated.
By their numbers in this assay, from the lowest: compound 2; then compounds 1 and 3 (each within the scatter of the next).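

In this assay, acetoxymethyl on this aromatic carbon, ortho to a large group, gives up the advantage held by neopentyloxy, with a 9.7-fold higher number from compound 2 to compound 3 (0.99 log units; beyond the scatter) as the second step at this position beyond the scatter. Set against isopropoxy, the same group gives a 1.7-fold higher number from compound 1 to compound 3 (0.22 log units; within the scatter) and so cannot be told apart from it, which leaves compound 2 alone as the strongest of the three, with its steps to both others beyond the scatter. Among these three compounds, only neopentyloxy stands apart, and nothing available explains why this position responds in this way.

The three groups do not show whether the standing of compound 2 belongs to the neopentyl group on the oxygen or to a wider class of ethers, and a longer chain such as n-pentyloxy or a benzyloxy group on this carbon would separate those readings. From the compounds shown here alone, it also stays open whether the ester matters within acetoxymethyl, which a hydroxymethyl group, a carboxylic acid or an amine at the same place would begin to test.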